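The source may hold more compounds than are shown below. What is called first, only, known or untested is meant among the compounds shown, and "the series" means these compounds.

Measured compounds:
- Compound 1, `CCCNc1nc(C#Cc2ccc(F)s2)nc2c1ncn2[C@H]1[C@H](O)[C@H](O)[C@]2(C(=O)NC)C[C@H]12`: 10.6 nM
- Compound 2, `CCNc1cc(C#Cc2ccc(F)s2)nc2c1ncn2[C@H]1[C@H](O)[C@H](O)[C@]2(C(=O)NC)C[C@H]12`: 25 nM
- Compound 3, `CNC(=O)[C@H]1O[C@@H](n2cnc3c(NC)nc(C#Cc4ccc(F)s4)nc32)[C@H](O)[C@@H]1O`: 1510 nM

In an assay on HEK293 cells for displacement of a labelled ligand from adenosine receptor A3 (Mus musculus) (a lower number here means a stronger inhibitor, a higher number a weaker inhibitor), compound 1 gives 10.6 nM, the lowest of the three numbers. Compound 2 comes nearest, with an inhibition constant 25 nM that lies beyond the usual scatter of this assay. Compound 3, which carries a different core from the other two, gives 1510 nM, far from compound 1.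

Compound 4, `CNC(=O)[C@@]12C[C@@H]1[C@@H](n1cnc3c(NC)nc(C#Cc4ccc(F)s4)nc31)[C@H](O)[C@@H]2O`, has not been measured. It differs from compound 1 in one place: hydrogen in place of ethyl on a saturated chain carbon bound to a nitrogen on an aromatic ring, so that a propylamino becomes a methylamino on the shared core of compound 1. Within the data shown here, no pair of measured compounds shows this exact change on this core, so its size can only be guessed. Compound 3 carries the same methylamino on another core and gives a high number, but that comparison mixes two changes at once and is not a clean guide.

For compound 4 a modest loss of potency relative to compound 1 is expected, with a step of a 2.8-fold higher number from compound 1 to compound 4 (0.45 log units; beyond the scatter) in this assay. The inhibition constant of compound 4 is estimated at 30 nM, within a range from 8 nM to 150 nM.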

Compound 4, inhibition constant: 85 nM
Beside the measured number, compound 4's estimate is 2.8-fold (0.45 log units) below it; low and high end bracket the measured number.
By their numbers in this assay, from the lowest: compound 1; then compound 2; then compound 4; then compound 3.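

In this assay, among these compounds, the change from propylamino to methylamino on the core of compound 1 gives an 8.0-fold higher number from compound 1 to compound 4 (0.90 log units; beyond the scatter), and this is the first direct reading of this change, since no earlier pair isolated it on this core. It shows that this position on the shared core responds to the length of the chain, as losing ethyl at this saturated chain carbon alone moves the number clearly, while compound 4, at 85 nM, keeps measurable binding with the short methylamino group. The compounds shown offer no measured property or other independent data that could account for the size of this step.

With only propylamino and methylamino compared on this core, the compounds leave open whether the number changes steadily with chain length or whether there is a sharp threshold, which an ethylamino group on the same core could settle. They also leave open whether a longer chain such as butylamino, a branched isopropylamino or a ring-bearing cyclopropylamino would match compound 1 or go further in either direction.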